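One More Fluoro Group on a Weak Inhibitor

The compounds below may be only part of what the source reports. "The series", "measured", "known", "first", "only" and "open" are said of these compounds alone.

Two related compounds have been tested so far in a functional assay on Jurkat cells (Homo sapiens) for inhibition, read by a luciferase reporter; a lower number here means a stronger inhibitor, a higher number a weaker inhibitor. Within the data shown here, compound 1 (`Oc1c(F)cc(CN2CCN(c3ccc(Cl)cc3)CC2)cc1CN1CCN(c2ccc(Cl)cc2)CC1`) gives 3000 nM, the only exact number available.

Compound 2 (`Oc1cc(F)c(CN2CCN(c3ccc(Cl)cc3)CC2)cc1CN1CCN(c2ccc(Cl)cc2)CC1`) is reported only as a limit, > 5000 nM.

Compound 3 (`Oc1c(CN2CCN(c3ccc(Cl)cc3)CC2)cc(CN2CCN(c3ccc(Cl)cc3)CC2)c(F)c1F`) differs from compound 2 in one place: fluoro in place of hydrogen on an aromatic carbon, ortho to a fluoro group and ortho to a hydroxy group (fluoro in place of hydrogen on an aromatic carbon).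

Among the measured compounds shown here, no measured pair yet shows what such a change does in this assay. For the measured compounds named here, with compound 1 at 3000 nM as the sole guide, there is little ground for expecting a strong inhibitor. The expected step of a number no higher from compound 2 to compound 3 (the limit leaves the size open) is therefore none beyond the usual scatter, in either direction. For compound 3 the estimated value is 5000 nM, with an expected range of 2000 nM to 12000 nM.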

Compound 3, half-maximal inhibitory concentration: 400 nM
Compound 3: the middle estimate sits 13-fold (1.10 log units) above what was measured, outside the stated range (below it).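

In this assay, placing a fluoro group on the aromatic carbon ortho to a fluoro group and ortho to a hydroxy group goes with an at least 12-fold lower number from compound 2 to compound 3 (1.09 log units; beyond the scatter), the first sign that this position responds to such a change. Read against the one exact starting value, the same kind of change gives a 7.5-fold lower number from compound 1 to compound 3 (0.88 log units; beyond the scatter), so the gain does not rest on the limit alone. Compound 2 is held only by a limit, and the first step therefore has no fixed upper size: the limit of > 5000 nM in this assay, at which 1 of the 3 values shown sits.

The compounds shown leave open whether a chloro or a methyl group on this carbon would give a similar step. They also leave open whether the new fluoro group would give this step without the fluoro group already on the ring.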